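This account rests on a few compounds, and the source may have more. Where it says the series, first, only, none or still open, it means among the compounds named here.

Among the measured compounds shown here, in a functional assay on MCF7 cells (Homo sapiens) for inhibition, read by trypan blue exclusion, with a stated time of 72 h (on this read-out higher numbers stand for weaker inhibition of growth and lower numbers for stronger inhibition of growth), compound 1 (`CC/C(=C(\c1ccc(NC(=O)C(C)C)cc1)c1ccc(OC)cc1)c1ccccc1`) gives 27900 nM, the only true number so far. Compound 2 (`CC/C(=C(\c1ccc(NC(=O)C(C)C)cc1)c1ccc(OC)cc1)c1ccc(OCc2ccccc2)cc1`) is reported only as a limit of the assay, > 30000 nM. For the measured compounds named here, the one measured step, an at least 1.0-fold higher number from compound 1 to compound 2 (0.03 log units; that floor lies within the scatter), therefore shows no real change, and it concerns benzyloxy in place of hydrogen on an aromatic carbon, not the change at hand.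

Compound 3 (`CC/C(=C(/c1ccc(O)cc1)c1ccc(NC(=O)C(C)C)cc1)c1ccccc1`) differs from compound 1 at a single place: hydrogen in place of methyl on an oxygen on an aromatic ring. This is hydrogen in place of methyl on an oxygen on an aromatic ring, or 4-methoxyphenyl to 4-hydroxyphenyl. Going by the values given here, no measured step touches that place, so any expectation stays loose. Compound 1, at 27900 nM, already sits close to the top of what the assay reports, so a visible move seems likelier toward stronger inhibition. The expected change is modest, a 2.3-fold lower number from compound 1 to compound 3 (0.37 log units; beyond the scatter). For compound 3 the estimate is 12000 nM, with an expected range from 3000 nM to 30000 nM.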

Compound 3, concentration for 50% growth inhibition: 16400 nM
Compound 3: the middle estimate sits 1.4-fold (0.14 log units) below what was measured; the range from low to high includes it.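

Among the compounds shown here, at this position, the first look at 4-methoxyphenyl to 4-hydroxyphenyl gives a 1.7-fold lower number from compound 1 to compound 3 (0.23 log units; within the scatter) in this assay. Taking the methyl off the oxygen on the aromatic ring therefore leaves the read-out indistinguishable from that of the parent, so this single pair does not separate methoxy from hydroxy at this place. Both numbers also lie in the same high range as the one compound reported only as a limit, compound 2, which leaves little of the scale visible on the weaker side: the limit of > 30000 nM in this assay, at which 1 of the 3 values shown sits.

Still open, from the compounds shown here alone, is whether a larger group on this oxygen, such as an ethyl or a longer chain, or an amine in place of the oxygen, would give a step beyond the scatter. Going by these compounds, it is also open whether a carboxylic acid at this place would move the number in either direction.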